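Removing a 4-Chlorobenzyl Group from an Inactive Amide

This account rests on a few compounds, and the source may have more. Where it says the series, first, only, none or still open, it means among the compounds named here.

Compound 2 `O=C(Nc1ccccc1)c1csc(-c2cn(Cc3ccc(Cl)cc3)c3ccccc23)n1` was tested in a functional assay on LNCaP C4-2 cells (Homo sapiens) for cytotoxicity, read by MTT assay, with a stated time of 48 h, in the absence of a further agent; a higher number here means a weaker inhibitor, a lower number a stronger inhibitor. In this assay compound 2 reaches only the limit of the measurement, > 100000 nM. Its relatives compound 1 `COc1ccc2[nH]cc(-c3nc(C(=O)Nc4cc(OC)c(OC)c(OC)c4)cs3)c2c1` and compound 3 `COc1cc(NC(=O)c2csc(-c3cn(Cc4ccc(Cl)cc4)c4ccccc34)n2)cc(OC)c1OC` were tested the same way. Compound 1 sits at a limit, > 100000 nM. Compound 3 gives a limit as well, > 100000 nM. For the measured compounds named here, the only measured step, a step that the two limits leave unreadable from compound 2 to compound 3, tells nothing about size because both of its ends rest at the limit of > 100000 nM in this assay, at which 3 of the 3 values shown sit. Compound 4 `O=C(Nc1ccccc1)c1csc(-c2c[nH]c3ccccc23)n1` differs from compound 2 by hydrogen in place of 4-chlorobenzyl on an aromatic nitrogen. Going by the values given here, no measured step bears on this change, and every value shown is a limit. Compound 4 is therefore expected to stay near that limit, a step that the limit leaves unreadable from compound 2 to compound 4. The estimate for compound 4 is 150000 nM, between 40000 nM and 1000000 nM.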

Compound 4, half-maximal inhibitory concentration: > 100000 nM
Compound 4 gave a limit, no number; the forecaster's own chance of this, stated with the estimate: 80%; the middle value lies beyond the limit too.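

Compound 2 and compound 4 both rest at a limit, so the size of the step between them cannot be read: the limit of > 100000 nM in this assay, at which 4 of the 4 values shown sit. The compounds shown leave open which change, if any, would give a measurable value in this assay.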